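The compounds below may be only part of what the source reports. "The series", "measured", "known", "first", "only" and "open" are said of these compounds alone.

Measured compounds:
compound 1 `CCCOC(=O)c1c(C)coc1-c1ccc2c(CC)cccc2c1OC` — > 10 ug/mL
compound 2 `CCc1cccc2c(OC)c(-c3occ(C)c3C(=O)On3nnc4ccccc43)ccc12` — > 10 ug/mL
compound 3 `CCOc1c(-c2occ(C)c2C(=O)OC)ccc2c(CC)cccc12` — 2.4 ug/mL

In a functional assay on A549 cells (Homo sapiens) for cytotoxicity, read by MTT assay, with a stated time of 72 h (on this read-out higher numbers stand for an effect only at larger amounts of compound and lower numbers for an effect already at smaller amounts), compound 1 gives only a limit, > 10 ug/mL, not a number. Compound 2 likewise stops at a limit, > 10 ug/mL. Within the data shown here, compound 3 gives a number, 2.4 ug/mL; compound 3 differs from compound 1 in two places, so no single step joins them. Among the measured compounds shown here, the one step measured from compound 1, a step that the two limits leave unreadable from compound 1 to compound 2, is not readable because both ends sit at the limit of > 10 ug/mL in this assay, at which 2 of the 3 values shown sit.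

Compound 4 `CCc1cccc2c(OC)c(-c3occ(C)c3COC)ccc12` is to be measured in this assay. Against compound 1 it carries methoxymethyl in place of propoxycarbonyl on an aromatic carbon. For the measured compounds named here, no measured step touches the propoxycarbonyl group; the expectation therefore rests only on where compound 1 stands. Compound 4 is expected at about 12 ug/mL, between 3 ug/mL and 40 ug/mL, which would mean an estimated step that the limit leaves unreadable from compound 1 to compound 4 of no readable size, most likely again a limit.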

Compound 4, concentration for half-maximal effect: > 10 ug/mL
Compound 4 ended at the assay's limit; the forecaster's own chance of this, stated with the estimate: 60%; the middle value does not contradict the limit.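

Compound 1 and compound 4 both stop at a limit, not a number, so no step can be read between them: the limit of > 10 ug/mL in this assay, at which 3 of the 4 values shown sit.

On these data alone, how methoxymethyl and propoxycarbonyl on the shared core compare remains open, as neither compound gives a number.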